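Ring-nitrogen methyl removal in a small aminoindazole-type series

The compounds below may be only part of what the source reports. "The series", "measured", "known", "first", "only" and "open" are said of these compounds alone.

Of the compounds shown here, three share one core and have been measured in an assay on isolated protein for inhibition of ribosomal protein S6 kinase alpha-5 (Homo sapiens), read by mobility shift assay, tested at 30 uM; on this read-out higher numbers stand for more inhibition at the one concentration tested (going by the name of the read-out) and lower numbers for less inhibition. Compound 1 `Cc1cc2c(c(N)nn2C)c(N2CCCCC2)n1` gives 7%, compound 2 `COCCNc1nc(C)cc2c1c(N)nn2C` gives 0%, and compound 3 `Cc1cc2c(cn1)c(N)nn2C` gives -2%. None of the three reaches a level of inhibition that stands out from the scatter. Compound 3 stands at the low end of the set only nominally: the change a number 9 percentage points lower from compound 1 to compound 3 (within the scatter) and the change a number 2 percentage points lower from compound 2 to compound 3 (within the scatter) both lie inside the scatter, as does a number 7 percentage points lower from compound 1 to compound 2 (within the scatter). All three measured steps concern the substituent on an aromatic carbon and say nothing about the ring nitrogen.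

Compound 4 `Cc1cc2[nH]nc(N)c2cn1` has not yet been measured. It differs from compound 3 by hydrogen in place of methyl on an aromatic nitrogen. For the measured compounds named here, no measured step touches this position, so the expectation rests on the measured compounds as a group: every one of them sits near the baseline of this assay, and every step among them is inside the scatter. On that basis no change beyond the scatter is expected; the step of a number 2 percentage points higher from compound 3 to compound 4 (within the scatter) is the estimate. Compound 4 is therefore expected to give about 0% in this assay, with a range from -10% to 10%.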

Compound 4, a percentage reported as inhibition, at one concentration (the size of the read-out at that concentration, not a potency): 13%
Compound 4: the middle estimate sits 13 percentage points below what was measured; the whole stated range lies below it.
By their numbers in this assay, from the lowest: compounds 3, 2, 1 and 4 (each within the scatter of the next, the first and the last beyond it).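

In this assay, the aromatic nitrogen of the five-membered aromatic ring with 2 nitrogen is the only position in the set where a single change passes the scatter: hydrogen in place of methyl there gives a number 15 percentage points higher from compound 3 to compound 4 (beyond the scatter), a modest step at a read-out of one concentration. This change removes just one heavy atom, whereas exchanges of much larger groups on the aromatic carbon stayed inside the scatter, as with a number 9 percentage points lower from compound 1 to compound 3 (within the scatter), so in this small set the ring nitrogen matters more to the read-out than that carbon substituent. Nothing measured here bears on what lies behind the step, which stands as an observation only.

As far as these compounds go, whether any group on this nitrogen lowers the number, or methyl alone does, remains open, and an ethyl group or a longer chain such as n-propyl at the same place would separate these two readings. Also open, from the compounds shown here alone, is whether the same exchange carries over to the cores bearing piperidin-1-yl or (2-methoxyethyl)amino on the aromatic carbon, and whether the step reflects a real difference in potency.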